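The compounds below may be only part of what the source reports. "The series", "measured", "known", "first", "only" and "open" are said of these compounds alone.

In a functional assay on CCRF-CEM cells (Homo sapiens), read by MTT assay, with a stated time of 72 h (a lower number here means a stronger inhibitor, a higher number a weaker inhibitor), compound 1 (`CSc1ncnc2c1c(-c1cccs1)cn2[C@@H]1O[C@H](CO)[C@@H](O)[C@H]1O`) gives > 20000 nM as a limit of the assay and not a number. Compound 2 (`CSc1ncnc2c1c(-c1ccccc1)cn2[C@@H]1O[C@H](CO)[C@@H](O)[C@H]1O`) likewise reads > 20000 nM as a limit. Compound 3 (`C#Cc1cn([C@@H]2O[C@H](CO)[C@@H](O)[C@H]2O)c2ncnc(SC)c12`) reads > 20000 nM and is also known only as a limit, so it has no exact place on the scale and stands level with the other two at the same ceiling (the limit of > 20000 nM in this assay, at which 3 of the 3 values shown sit). The next compound, compound 4 (`C#Cc1cn([C@@H]2O[C@H](CO)[C@@H](O)[C@H]2O)c2ncnc(N(C)C)c12`), carries dimethylamino in place of methylsulfanyl on an aromatic carbon. The measured steps a step that the two limits leave unreadable from compound 1 to compound 2 and a step that the two limits leave unreadable from compound 1 to compound 3 and a step that the two limits leave unreadable from compound 2 to compound 3 exchange thiophen-2-yl, phenyl and ethynyl, and none of them touches methylsulfanyl, so they give no direct measure for this change. With all three values at the limit, only a modest move toward a stronger inhibitor is expected, and the estimated step is an at least 1.3-fold lower number from compound 3 to compound 4 (0.12 log units; that floor lies within the scatter) in this assay with much uncertainty. Compound 4 is expected at 15000 nM within an estimated range from 2000 nM to 30000 nM and may well report only a limit.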

Compound 4, half-maximal inhibitory concentration: 90 nM
The estimate for compound 4 lay 170-fold (2.22 log units) above the measured number; the whole stated range lies above it.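

The earlier compounds shown here all carried methylsulfanyl and exchanged only thiophen-2-yl, phenyl and ethynyl, so their steps could not be read and said nothing about this position. With ethynyl kept in place, dimethylamino in place of methylsulfanyl on this aromatic carbon, next to the ring nitrogen, gives an at least 220-fold lower number from compound 3 to compound 4 (2.34 log units; beyond the scatter) in this assay, which shows that activity in these cells depends strongly on the group held here. Compound 4 is the only compound shown that comes off the ceiling: the limit of > 20000 nM in this assay, at which 3 of the 4 values shown sit.

From the compounds shown here alone, it remains open whether dimethylamino would give a comparable step with thiophen-2-yl or phenyl in place of ethynyl. Going by these compounds, it is also open how far the result extends to other groups on the same carbon, such as a primary amine, methylamino or methoxy.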